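Nitrile cathepsin S inhibitors: swapping the ether substituent

The source may report more compounds than this note shows. Statements on the series, on what has been measured and on what is new or still open speak of the compounds shown alone.

Measured compounds:
Compound 1, `N#Cc1nc(-c2cccc(C(F)(F)F)c2)cc2[nH]cnc12`, in an assay on isolated protein for inhibition of cathepsin S (Homo sapiens), read by fluorescence (on this read-out lower numbers stand for stronger inhibition and higher numbers for weaker inhibition), gives 1050 nM.
Compound 2, `Cn1cnc2c(C#N)nc(-c3ccc(OCc4cccnc4)c(C(F)(F)F)c3)cc21`, in this assay gives 12.6 nM.

Two compounds share a nitrile-bearing core, and both have been tested in this assay. Compound 1 carries only a trifluoromethyl-substituted phenyl ring on that core and in this assay gives 1050 nM. Compound 2 adds a methyl on the core and a (pyridin-3-yl)methoxy group on the phenyl ring, and in this assay it gives 12.6 nM, the lower of the two numbers; the gap to compound 1 is well beyond the usual scatter. Because the two compounds differ in more than one place, their values alone do not say which change carries the gain.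

Compound 3, `Cn1cnc2c(C#N)nc(-c3ccc(OC4CCNCC4)c(C(F)(F)F)c3)cc21`, has not yet been measured. It differs from compound 2 in one place: piperidin-4-yl in place of (pyridin-3-yl)methyl on an oxygen on an aromatic ring. The group that enters is similar in size to the one that leaves, and the rest of compound 2 is kept. Among the compounds with values here, with no measured pair of this kind to guide the expectation, the step from compound 2 to compound 3 is expected to be small, around a 1.6-fold higher number from compound 2 to compound 3 (0.20 log units; within the scatter), within or just beyond the scatter. Compound 3 is therefore expected to give about 20 nM in this assay, with a range of 5 nM to 80 nM.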

Compound 3, half-maximal inhibitory concentration: 316 nM
Compound 3: the middle estimate sits 16-fold (1.20 log units) below what was measured; the measured number lies above the stated range.
By their numbers in this assay, from the lowest: compound 2; then compound 3; then compound 1.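

Within the data shown here, compounds 2 and 3 form the first pair here that differs in only one place, so the group on this oxygen can finally be judged on its own: in this assay, changing (pyridin-3-yl)methoxy to (piperidin-4-yl)oxy gives a 25-fold higher number from compound 2 to compound 3 (1.40 log units; beyond the scatter). At this position, then, two groups of similar size are far from interchangeable, and the low number of compound 2 depends strongly on which group sits on the oxygen, something the comparison of compound 1 with compound 2 could not show. No measurement shown here accounts for the size of this step.

The change alters several things at once, from an aromatic ring to a non-aromatic one, the gain of a hydrogen-bond donor, and the loss of the carbon that links the ring to the oxygen, and the compounds shown do not separate these. On these data alone, a benzyl group or a (piperidin-4-yl)methyl group on the same oxygen would test these features one at a time, while the share of the methyl on the core in the gap between compound 1 and compound 2 also remains open.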